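This account rests on a few compounds, and the source may have more. Where it says the series, first, only, none or still open, it means among the compounds named here.

Compound 1 `N#Cc1c(NN)nc(SCc2nc3ccccc3[nH]2)nc1-c1ccccc1` gives 2.55 nM
Compound 2 `CCNc1nc(SCc2nc3ccccc3[nH]2)nc(-c2ccccc2)c1C#N` gives 7.35 nM

In a functional assay on RKOp27 cells (Homo sapiens) for cytotoxicity, read by MTT assay, with a stated time of 3 days (on this read-out higher numbers stand for weaker inhibition and lower numbers for stronger inhibition), compound 2 gives 7.35 nM, the higher of the two numbers, so it is the weaker inhibitor of this pair. Compound 3 `N#Cc1c(Nc2ccccn2)nc(SCc2nc3ccccc3[nH]2)nc1-c1ccccc1` keeps the shared core and changes one group: pyridin-2-yl in place of ethyl on a nitrogen on an aromatic ring. In words, this is pyridin-2-yl in place of ethyl on a nitrogen on an aromatic ring, or ethylamino to (pyridin-2-yl)amino.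

Among the measured compounds shown here, only one measured step involves this same place: a 2.9-fold higher number from compound 1 to compound 2 (0.46 log units; beyond the scatter). For the measured compounds named here, that step is modest and beyond the scatter, and it gives the only available scale for changes on this nitrogen. It cannot show how a pyridin-2-yl group will behave, since neither measured compound carries a ring there. The data therefore favour no clear direction, and a step of no more than similar modest size is expected in this assay. The expected change is a 1.2-fold lower number from compound 2 to compound 3 (0.09 log units; within the scatter), which is estimated to be within the scatter. For compound 3 the estimate is 6 nM, with an expected range from 1.5 nM to 20 nM.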

Compound 3, half-maximal inhibitory concentration: 3.8 nM
Beside the measured number, compound 3's estimate is 1.6-fold (0.20 log units) above it; measured number inside the range.
By their numbers in this assay, from the lowest: compounds 1, 3 and 2 (each within the scatter of the next, the first and the last beyond it).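

Replacing ethyl with pyridin-2-yl on this nitrogen gives a 1.9-fold lower number from compound 2 to compound 3 (0.29 log units; within the scatter) in this assay, and replacing amino with pyridin-2-yl gives a 1.5-fold higher number from compound 1 to compound 3 (0.17 log units; within the scatter). Compound 3 is the first compound shown with a ring at this place, and its six-membered aromatic group has 6 heavy atoms against the 2 of ethyl, yet its number cannot be told apart from that of either compound 1 or compound 2. A ring on this nitrogen is therefore compatible with a cytotoxic potency in the same range as these two compounds, even though compound 1 and compound 2 themselves differ beyond the scatter.

Nothing available explains this result. On these data alone, it remains open whether the ring nitrogen of pyridin-2-yl matters, which a plain phenyl group at the same place could test, and whether a longer chain such as butyl would keep the number in this range.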